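From 3-chlorophenyl to 4-chlorophenyl in compound 2

The compounds below may be only part of what the source reports. "The series", "measured", "known", "first", "only" and "open" are said of these compounds alone.

Measured so far in a functional assay on DU-145 cells (Homo sapiens) for cytotoxicity, read by MTT assay; on this read-out higher numbers stand for weaker inhibition and lower numbers for stronger inhibition:
- Compound 1 `COc1ccc2cc([C@H](C)c3nnc(SCc4ccccc4)n3-c3ccc(Cl)cc3)ccc2c1`: 35800 nM
- Compound 2 `COc1ccc2cc([C@H](C)c3nnc(SCc4c(Cl)cccc4Cl)n3-c3cccc(Cl)c3)ccc2c1`: <= 400000 nM (a limit)

Compound 2 is known only through a limit, <= 400000 nM, so no exact number fixes where it stands in this assay. Compound 3 `COc1ccc2cc([C@H](C)c3nnc(SCc4c(Cl)cccc4Cl)n3-c3ccc(Cl)cc3)ccc2c1` has not yet been measured. It differs from compound 2 in one place, with 4-chlorophenyl in place of 3-chlorophenyl on an aromatic nitrogen. Compound 3 keeps the (2,6-dichlorobenzyl)sulfanyl group of compound 2 and shares the 4-chlorophenyl of compound 1. Among the measured compounds shown here, no measured pair shows what this change does on its own, so the expectation leans on compound 1 at 35800 nM. In this assay the expected step, towards lower numbers, is a step that the limit leaves unreadable from compound 2 to compound 3. For compound 3 the estimate is 40000 nM, with an expected range from 10000 nM to 160000 nM.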

Compound 3, half-maximal inhibitory concentration: 36100 nM
Compound 3: the middle estimate sits 1.1-fold (0.04 log units) above what was measured; measured number inside the range.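

In this assay, with the 4-chlorophenyl held in place on the aromatic nitrogen, 2,6-dichlorophenyl in place of phenyl on the saturated chain carbon bound to a sulfur gives a 1.0-fold higher number from compound 1 to compound 3 (0.00 log units; within the scatter). This is the first pair shown that differs in one place and has a readable step, and at this position it separates the two chlorine atoms on the benzyl ring from any measurable difference in this one pair. Compound 2 is known only through a limit, so the step for 4-chlorophenyl in place of 3-chlorophenyl cannot be read: the limit of <= 400000 nM in this assay, at which 1 of the 3 values shown sits.

Going by these compounds, whether moving the chlorine on the ring at the aromatic nitrogen matters at all therefore stays open. Also open, on these data alone, is whether an amine or a carboxylic acid on the benzyl ring, in place of chlorine, would give a readable step in this assay.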